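This account rests on a few compounds, and the source may have more. Where it says the series, first, only, none or still open, it means among the compounds named here.

Compound 3 `Cc1ccnc(NC(c2ccccc2C)c2ccc3cccnc3c2O)c1` is measured only as a limit in an assay for inhibition of protein disulfide-isomerase (Homo sapiens), with a stated time of 1 h; a higher number here means a weaker inhibitor, a lower number a stronger inhibitor: compound 3 gives > 40000 nM, which marks the limit of > 40000 nM in this assay, at which 1 of the 3 values shown sits, rather than a number. Compound 1 `Cc1ccnc(NC(c2ccc(F)cc2)c2ccc3cccnc3c2O)c1` carries a 4-fluorophenyl group where compound 3 carries a 2-methylphenyl group. In this assay compound 1 gives 140 nM. That change in this assay gave an at least 280-fold higher number from compound 1 to compound 3 (2.45 log units; beyond the scatter), a large loss of inhibition. Compound 2 `Oc1ccc2ncccc2c1C(c1ccc(F)cc1)N1CCCCC1` also reaches only a limit, namely > 30000 nM, which is the limit of > 30000 nM in this assay, at which 1 of the 3 values shown sits, and not a measured number.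

Compound 4 `Cc1ccnc(NC(c2ccc3cccnc3c2O)c2c(Cl)cccc2Cl)c1` differs from compound 3 by 2,6-dichlorophenyl in place of 2-methylphenyl on a saturated chain carbon bound to an aromatic carbon and a nitrogen on an aromatic ring. For the measured compounds named here, the one measured step at this position is an at least 280-fold higher number from compound 1 to compound 3 (2.45 log units; beyond the scatter), and it shows that replacing the 4-fluorophenyl group with a 2-methylphenyl group drove the value past the limit of the assay; compound 4 again carries a substituted phenyl group rather than the 4-fluorophenyl group. No change beyond the scatter is therefore expected in this assay, so the estimated step is a step that the limit leaves unreadable from compound 3 to compound 4. Compound 4 is expected to give about 60000 nM, with a likely range from 10000 nM to 300000 nM, and most likely the assay would again report only a limit.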

Compound 4, half-maximal inhibitory concentration: > 40000 nM
Compound 4 ended at the assay's limit (the forecaster's own chance of this, stated with the estimate: 75%); the middle value lies beyond the limit too.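

Compound 4 gives > 40000 nM in this assay, which is a limit and not a number, and compound 3 stands at the same limit: the limit of > 40000 nM in this assay, at which 2 of the 4 values shown sit. Putting 2,6-dichlorophenyl in place of the 4-fluorophenyl group gives an at least 280-fold higher number from compound 1 to compound 4 (2.45 log units; beyond the scatter), so among the compounds shown, the large loss is not confined to the 2-methylphenyl group. With both values at a limit, the step between compound 3 and compound 4 cannot be read, and nothing can be said about how 2,6-dichlorophenyl and 2-methylphenyl rank against each other.

As far as these compounds go, only the 4-fluorophenyl group gives a measured number at this position, so how much of its inhibition other groups could keep remains unknown. A plain phenyl group or a pyridyl group at this position would help to show this.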